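Swapping hydroxy for nitro on a weakly cytotoxic core

This account rests on a few compounds, and the source may have more. Where it says the series, first, only, none or still open, it means among the compounds named here.

Compound 1 `O=C(/C=C\c1ccc(O)cc1)N1N=C(c2ccncc2)OC1c1c[nH]c2ccccc12` was tested in an ADME assay on A549 cells (Homo sapiens) for cytotoxicity, read by MTT assay, with a stated time of 48 h; a lower number here means a stronger inhibitor of growth, a higher number a weaker inhibitor of growth. In this assay compound 1 gives > 30 ug/mL, which is a limit of the assay rather than a number. Compound 2 `O=C(/C=C\c1cccc([N+](=O)[O-])c1)N1N=C(c2ccncc2)OC1c1c[nH]c2ccccc12`, in which 3-nitrophenyl replaces 4-hydroxyphenyl, gives in this assay > 30 ug/mL, also a limit. The step that the two limits leave unreadable from compound 1 to compound 2 is therefore unreadable, both values sitting at the limit of > 30 ug/mL in this assay, at which 2 of the 2 values shown sit. Compound 3 `O=C(/C=C\c1ccc([N+](=O)[O-])cc1)N1N=C(c2ccncc2)OC1c1c[nH]c2ccccc12` has not yet been measured. It differs from compound 1 by nitro in place of hydroxy on an aromatic carbon. Going by the values given here, only the step from compound 1 to compound 2 bears on this change, and that step cannot be read, so no step beyond the scatter can be expected in this assay; a value at the limit again is the most likely outcome. Compound 3 is therefore estimated at 40 ug/mL, with a range from 20 ug/mL to 100 ug/mL, which means an expected step that the limit leaves unreadable from compound 1 to compound 3.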

Compound 3, concentration for 50% growth inhibition: > 30 ug/mL
Compound 3: a limit, no number; the forecaster's own chance of this, stated with the estimate: 75%; the middle value is on the limit's open side.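

Compound 3 also stands at a limit, so no new step can be read from compound 1 or compound 2 to compound 3: the limit of > 30 ug/mL in this assay, at which 3 of the 3 values shown sit.

The compounds shown leave open whether 4-hydroxyphenyl, 3-nitrophenyl and 4-nitrophenyl differ at all in this assay.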